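The compounds below may be only part of what the source reports. "The series", "measured", "known", "first", "only" and "open" are said of these compounds alone.

Measured in a functional assay with Oryctolagus cuniculus as the target; on this read-out lower numbers stand for stronger inhibition and higher numbers for weaker inhibition:
- compound 1 `COc1ccc(-c2nc(CN)sc2-c2ccc(OC)cc2)cc1`: > 100 nM, a limit
- compound 2 `COc1ccc(-c2nc(CCC(=O)O)sc2-c2ccc(OC)cc2)cc1`: < 100 nM, a limit

Compound 2 is known only by its limit of < 100 nM. Compound 3 `COc1ccc(-c2nc(C3=CCN(C)CC3)sc2-c2ccc(OC)cc2)cc1` differs from it as follows: a group of 7 heavy atoms (6 carbon, 1 nitrogen; one six-membered non-aromatic ring with 1 hetero atom) in place of a group of 5 heavy atoms (3 carbon, 2 oxygen; no ring), on an aromatic carbon. Within the data shown here, the only measured step, a number no higher from compound 1 to compound 2 (the limit leaves the size open), has no readable size, so it fixes no expected size. The entering group holds a nitrogen, as does the group of compound 1, which stands at its limit of > 100 nM. In this assay the expected change is an at least 1.5-fold higher number from compound 2 to compound 3 (0.17 log units; that floor lies within the scatter), towards weaker inhibition, and this expectation is loose. For compound 3 the estimate is 150 nM, with an expected range from 20 nM to 1000 nM.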

Compound 3, half-maximal inhibitory concentration: < 10 nM
Compound 3: no number, only a limit; the forecaster's own chance of this, stated with the estimate: 45%; at least 15-fold (1.17 log units) between middle value and limit.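

In this assay, compound 3 gives < 10 nM, a limit. A nitrogen in the group on this aromatic carbon therefore does not by itself go with weaker inhibition, since the step with the six-membered non-aromatic ring in place of the shorter nitrogen-bearing group is an at least 10-fold lower number from compound 1 to compound 3 (1.00 log units; beyond the scatter). The step between compound 2 and compound 3 cannot be read, as both values are limits.

Which part of the entering group matters remains open. The same ring without its double bond, or without the methyl on its nitrogen, would help separate these features.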